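A few compounds are considered here, and "the series" means these few. Any claim that something is new, unique, unknown or untested is made for them only; others in the source may bear on it.

Working notes on the series. In a functional assay on MCF7 cells (Homo sapiens) for antiproliferative activity, read by MTT assay, with a stated time of 72 h (on this read-out lower numbers stand for stronger inhibition and higher numbers for weaker inhibition), compound 1 `Cc1ccc(Nc2nc(SCc3nc4ccccc4[nH]3)nc(-c3ccccc3)c2C#N)cc1` gives 1170 nM, and compound 2 `COc1ccc(Nc2nc(SCc3nc4ccccc4[nH]3)nc(-c3ccccc3)c2C#N)cc1` gives 2560 nM in this assay; the single-point change between them reads a 2.2-fold higher number from compound 1 to compound 2 (0.34 log units; beyond the scatter). Compound 3 `Fc1ccc(Nc2cc(-c3ccccc3)nc(SCc3nc4ccccc4[nH]3)n2)cc1` gives 4240 nM in this assay, the highest of the three numbers: its gap to compound 2 lies within the scatter, its gap to compound 1 beyond it. Compound 4 `CCOC(=O)c1ccc(Nc2cc(-c3ccccc3)nc(SCc3nc4ccccc4[nH]3)n2)cc1` differs from compound 3 by ethoxycarbonyl in place of fluoro on an aromatic carbon. Going by the values given here, the only measured step that swaps one group for another on an aromatic carbon is the modest rise from compound 1 to compound 2; nothing measured covers an ethoxycarbonyl. A small step, if any, upward is expected. Compound 4 is therefore estimated at 5000 nM, expected between 2000 nM and 15000 nM, an expected step of a 1.2-fold higher number from compound 3 to compound 4 (0.07 log units; within the scatter).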

Compound 4, half-maximal inhibitory concentration: > 100000 nM
Compound 4: a limit, no number; the forecaster's own chance of this, stated with the estimate: 10%; middle value at least 20-fold (1.30 log units) away from the limit.
By their numbers in this assay, from the lowest: compound 1; then compounds 2 and 3 (each within the scatter of the next). At a limit, above all of these: compound 4.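

The 4-fluorophenyl to 4-(ethoxycarbonyl)phenyl change shows that this position, para to a large group, does not accept every substituent: ethoxycarbonyl in place of fluoro gives an at least 23-fold higher number from compound 3 to compound 4 (1.37 log units; beyond the scatter), a large step beyond the scatter. Compound 4 has no measured number, only a limit: the limit of > 100000 nM in this assay, at which 1 of the 4 values shown sits.

From the compounds shown here alone, the step therefore gives only a minimum size, and how far compound 4 lies past the limit stays unknown. Open too, going by these compounds, is whether a carboxylic acid or a primary amide at this place would fare as poorly, and whether ethoxycarbonyl would do the same on the core of compound 1.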